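The source may hold more compounds than are shown below. What is called first, only, known or untested is meant among the compounds shown, and "the series" means these compounds.

Measured so far:
compound 1 `COc1cc(-c2nn(-c3ccc(NC(=O)c4ccc(Cl)c(C(F)(F)F)c4)cc3)cc2-c2ccncc2)ccc1Cl` — 1920 nM
compound 2 `O=C(Nc1ccc(-n2cc(-c3ccncc3)c(-c3ccc(Cl)c(O)c3)n2)cc1)c1cc(Cl)cc(Cl)c1` — 1510 nM

In a functional assay on M14 cells (Homo sapiens) for antiproliferative activity, read by sulforhodamine B assay, with a stated time of 48 h (on this read-out higher numbers stand for weaker inhibition and lower numbers for stronger inhibition), compound 2 gives 1510 nM, the lower of the two numbers recorded, while compound 1 gives 1920 nM; the gap between them lies within the scatter, so neither can be called the stronger inhibitor. The step to compound 3 `O=C(Nc1ccc(-n2cc(-c3ccncc3)c(-c3ccc(Cl)c(O)c3)n2)cc1)c1ccc(Cl)c(C(F)(F)F)c1` is a change of the aryl group on the amide carbonyl: 4-chloro-3-(trifluoromethyl)phenyl in place of 3,5-dichlorophenyl on a carbonyl carbon. Among the compounds with values here, no measured pair isolates this change. Compound 1 already carries the 4-chloro-3-(trifluoromethyl)phenyl group that enters here, and in this assay compound 1 gives 1920 nM, a value close to that of compound 2. On that basis no step beyond the scatter is expected. Compound 3 is therefore estimated at 1700 nM, with a range from 800 nM to 3600 nM, meaning an expected step of a 1.1-fold higher number from compound 2 to compound 3 (0.05 log units; within the scatter).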

Compound 3, half-maximal inhibitory concentration: 840 nM
Compound 3: the middle estimate sits 2.0-fold (0.31 log units) above what was measured; low and high end bracket the measured number.
By their numbers in this assay, from the lowest: compounds 3, 2 and 1 (each within the scatter of the next, the first and the last beyond it).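

In this assay, 4-chloro-3-(trifluoromethyl)phenyl in place of 3,5-dichlorophenyl on a carbonyl carbon gives a 1.8-fold lower number from compound 2 to compound 3 (0.25 log units; within the scatter), so the two aryl groups cannot be told apart at this position. With 4-chloro-3-(trifluoromethyl)phenyl held constant, hydrogen in place of methyl on an oxygen on an aromatic ring gives a 2.3-fold lower number from compound 1 to compound 3 (0.36 log units; beyond the scatter), a modest step and the only one here that clears the scatter. No measurement is available that would account for either step.

Whether the effect of hydrogen on that oxygen also holds with 3,5-dichlorophenyl on the carbonyl remains open, as the compounds shown offer only one such pair. Also open, as far as these compounds go, is how a longer chain on that oxygen, or an amine or a carboxylic acid on the aryl group, would read in this assay.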